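From carboxy to methoxy on a shared core

A few compounds are considered here, and "the series" means these few. Any claim that something is new, unique, unknown or untested is made for them only; others in the source may bear on it.

Measured so far in a functional assay on A549 cells (Homo sapiens) for cytotoxicity, read by MTT assay, with a stated time of 72 h; a lower number here means a stronger inhibitor, a higher number a weaker inhibitor
- compound 1 (`COc1cc(/C=C2\COC/C(=C\c3ccccc3F)C2=O)ccc1O`) gives 21400 nM
- compound 2 (`O=C1/C(=C/c2ccccc2F)COC/C1=C\c1ccccc1C(=O)O`) gives 27900 nM

Compound 2 stands at 27900 nM in this assay and cannot be told apart from compound 1 at 21400 nM in this read-out, since the two values lie within the usual scatter of each other. With only these two compounds measured, the numbers show no trend.

The next compound to be tested is compound 3 (`COc1ccccc1/C=C1\COC/C(=C\c2ccccc2F)C1=O`). It keeps the core of compound 2 but carries methoxy in place of carboxy on an aromatic carbon, at a place that is ortho to a large group.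

Going by the values given here, no measured pair shows what this exchange does, so the expectation rests on little. The two values in hand sit close together, which gives no reason to expect a large move. The estimated step of a 1.6-fold lower number from compound 2 to compound 3 (0.19 log units; within the scatter) is a small one toward a lower number, not expected to clear the scatter. For compound 3 the expected value is 18000 nM in this assay, with an estimated range from 7000 nM to 45000 nM for the measurement.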

Compound 3, half-maximal inhibitory concentration: 5900 nM
Beside the measured number, compound 3's estimate is 3.1-fold (0.48 log units) above it; measured number below the stated range.
By their numbers in this assay, from the lowest: compound 3; then compounds 1 and 2 (each within the scatter of the next).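

In this assay, the exchange of carboxy for methoxy on an aromatic carbon ortho to a large group gives a modest step, a 4.7-fold lower number from compound 2 to compound 3 (0.67 log units; beyond the scatter), and this one lies beyond the scatter. Going by these compounds alone, compounds 1 and 2 differ in more than one place and offered no step, so this is the first reading of what a single change at this position can do. The change takes out carboxy, with its hydrogen-bond donor, and puts in methoxy, which has none, and the lower number comes with that exchange on an otherwise unchanged core. Nothing measured here accounts for the step.

With one pair, the compounds shown cannot tell whether the step comes from the arrival of methoxy or from the departure of carboxy, and neither a bare hydrogen, a hydroxyl, an ethoxy group nor an amine at this carbon is among them to separate the two. On these data alone, it also stays open whether the same exchange would give a step of this size on another core or at another carbon of this ring.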